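Hydroxy added to the acetyl chain of compound 1

The source may hold more compounds than are shown below. What is called first, only, known or untested is meant among the compounds shown, and "the series" means these compounds.

Measured in a functional assay on HCT-15 cells (Homo sapiens); on this read-out lower numbers stand for an effect already at smaller amounts and higher numbers for an effect only at larger amounts of compound:
- compound 1 `COc1cc(C2OC(c3ccc(N(C)C)cc3)=NN2C(C)=O)cc(OC)c1OC`: 0.033 uM
- compound 2 `COc1cc(C2OC(c3ccccc3N(C)C)=NN2C(C)=O)cc(OC)c1OC`: 65 uM
- compound 3 `COc1cc(C2OC(c3cccc(N(C)C)c3)=NN2C(C)=O)cc(OC)c1OC`: 0.16 uM

Compound 1 has the lowest number of the three, and its steps to both others lie beyond the scatter. The nearest is a 4.8-fold higher number from compound 1 to compound 3 (0.69 log units; beyond the scatter), a modest step. The furthest is a 2000-fold higher number from compound 1 to compound 2 (3.29 log units; beyond the scatter), a large step.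

The next compound is compound 4 `COc1cc(C2OC(c3ccc(N(C)C)cc3)=NN2C(=O)CO)cc(OC)c1OC`, not yet measured. It carries hydroxy in place of hydrogen on a saturated chain carbon bound to a carbonyl carbon, which turns the acetyl group of compound 1 into (hydroxymethyl)carbonyl.

All measured steps exchange one (dimethylamino)phenyl group for another, including a 410-fold lower number from compound 2 to compound 3 (2.61 log units; beyond the scatter). None alters the acetyl group, so the data hold no direct measure of this change. These steps show only that this assay can move widely within the series, and this argues for a broad range rather than for a direction.

With the (dimethylamino)phenyl group of compound 1 kept, the step expected in this assay is a 1.8-fold higher number from compound 1 to compound 4 (0.26 log units; within the scatter), so no clear change is anticipated. For compound 4 the estimated value is 0.06 uM, with an expected range of 0.012 uM to 0.3 uM.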

Compound 4, concentration for half-maximal effect: 0.026 uM
The estimate for compound 4 lay 2.3-fold (0.36 log units) above the measured number; the range from low to high includes it.
By their numbers in this assay, from the lowest: compounds 4 and 1 (each within the scatter of the next); then compound 3; then compound 2.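

In this assay, within the data shown here, hydroxy in place of hydrogen on a saturated chain carbon bound to a carbonyl carbon gives a 1.3-fold lower number from compound 1 to compound 4 (0.10 log units; within the scatter), the first reading at the acetyl group, and the two compounds cannot be told apart. All earlier steps exchanged one (dimethylamino)phenyl group for another and said nothing about this position; now, with the 4-(dimethylamino)phenyl group kept, (hydroxymethyl)carbonyl is seen to stand in place of acetyl with the number still in the range of compound 1. Nothing available bears on the reason for this result.

On these data alone, how far this position accepts other groups stays open: an aminomethyl carbonyl with its amine, a carboxylic acid, or a longer chain such as propionyl could each show whether the flat reading holds beyond this single exchange. As far as these compounds go, it is also open whether the same exchange of acetyl for (hydroxymethyl)carbonyl would read alike on the 3-(dimethylamino)phenyl group of compound 3 or the 2-(dimethylamino)phenyl group of compound 2.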